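Amine swap on the shared core, compound 3 forecast

This account rests on a few compounds, and the source may have more. Where it says the series, first, only, none or still open, it means among the compounds named here.

Among the measured compounds shown here, in a functional assay on HEK293 cells for antagonist activity at transient receptor potential cation channel subfamily V member 1 (Rattus norvegicus), read by calcium flux (on this read-out lower numbers stand for stronger inhibition and higher numbers for weaker inhibition), compound 2 `CCN(CC)c1nc(Nc2ccc(C(F)(F)F)cc2)c2nc(Nc3c(Cl)cccc3Cl)sc2n1` gives 34 nM, and compound 1 `FC(F)(F)c1ccc(Nc2nc(N3CCCC3)nc3sc(Nc4c(Cl)cccc4Cl)nc23)cc1` gives 36 nM; the only measured step is a 1.1-fold lower number from compound 1 to compound 2 (0.02 log units; within the scatter), so the two stand together within the scatter. Compound 3 `CC(C)CNc1nc(Nc2ccc(C(F)(F)F)cc2)c2nc(Nc3c(Cl)cccc3Cl)sc2n1` carries isobutylamino in place of diethylamino on an aromatic carbon. For the measured compounds named here, the step from compound 1 to compound 2 also exchanged one amine for another at this position and stayed within the scatter, which is the only step that bears on this change; no measured pair shows what the entering donor does. Compound 3 is therefore expected near compound 2 in this assay, with a step of a 1.2-fold higher number from compound 2 to compound 3 (0.07 log units; within the scatter) within the scatter. The estimate for compound 3 is 40 nM, between 15 nM and 110 nM.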

Compound 3, half-maximal inhibitory concentration: 1 nM
The estimate for compound 3 lay 40-fold (1.60 log units) above the measured number, and the stated range ends above it.
By their numbers in this assay, from the lowest: compound 3; then compounds 2 and 1 (each within the scatter of the next).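

In this assay, the amine at this position, between two ring nitrogen atoms, is not interchangeable: a 34-fold lower number from compound 2 to compound 3 (1.53 log units; beyond the scatter), and a 36-fold lower number from compound 1 to compound 3 (1.56 log units; beyond the scatter), whereas the exchange from compound 1 to compound 2 stayed within the scatter. At an equal heavy-atom count, isobutylamino brings one hydrogen-bond donor where diethylamino has none. Nothing available explains the step. Still open, going by these compounds, is whether the amine hydrogen or the branched chain goes with the large step. A straight-chain butylamino or an isobutoxy group at this position would separate the two.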